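The source may hold more compounds than are shown below. What is called first, only, known or untested is meant among the compounds shown, and "the series" means these compounds.

Measured compounds:
Compound 1 `Nc1cccc(Nc2c(C(=O)NCc3ccc(F)cc3)nc(Br)c3cccnc23)c1`: 8000 nM
Compound 2 `O=C(NCc1ccc(F)cc1)c1nc(Br)c2cccnc2c1NCCCNc1c(C(=O)NCc2ccc(F)cc2)nc(Br)c2cccnc12`: "not determined" (no result reported)

In a functional assay on MCF7 cells (Homo sapiens) for cytotoxicity, read by MTT assay, with a stated time of 72 h (a higher number here means a weaker inhibitor, a lower number a stronger inhibitor), compound 1 gives 8000 nM. Going by the values given here, this is the only number available, so compound 1 cannot be ranked against anything. Compound 2 was entered in the same test but has no reported result and offers no comparison.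

The next compound to be tested is compound 3 `NCCCNc1c(C(=O)NCc2ccc(F)cc2)nc(Br)c2cccnc12`. It keeps the core of compound 1 and carries 3-aminopropyl in place of 3-aminophenyl on a nitrogen on an aromatic ring. The ring of the departing group is therefore replaced by an open chain.

Among the compounds with values here, no measured pair shows what such a change does, so any forecast rests on compound 1 at 8000 nM and on the structural change alone. A moderate step towards a lower number is expected in this assay, although a step no larger than the scatter would not be surprising. The estimate corresponds to an expected 2.3-fold lower number from compound 1 to compound 3 (0.36 log units; beyond the scatter). For compound 3 the expected value is 3500 nM, with an estimated range from 900 nM to 13000 nM.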

Compound 3, half-maximal inhibitory concentration: 6000 nM
Compound 3: middle estimate off by 1.7-fold (0.23 log units), on the low side, within the range that was stated.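

In this assay, going by these compounds alone, putting 3-aminopropyl in place of 3-aminophenyl on a nitrogen on an aromatic ring amounts to a 1.3-fold lower number from compound 1 to compound 3 (0.12 log units; within the scatter), so this single pair gives the first reading of what a change at this place does. The six-membered aromatic ring of 3-aminophenyl can therefore give way to the open chain of 3-aminopropyl, with the amine kept and the rest of the core of compound 1 unchanged, and the two compounds cannot be told apart in this test. Nothing measured on these compounds accounts for this outcome, and it remains one observation on one pair rather than a pattern.

The compounds shown leave open whether any other group at this nitrogen, such as a longer chain, a shorter chain, or a chain ending in a hydroxyl group or a carboxylic acid in place of the amine, would give a step beyond the scatter. They also leave open whether a ring carrying its amine elsewhere, such as 4-aminophenyl or a piperidine, would read the same as compound 1 and compound 3.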